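The source may report more compounds than this note shows. Statements on the series, on what has been measured and on what is new or still open speak of the compounds shown alone.

Series notes. In an assay on FRT cells with Cystic fibrosis transmembrane conductance regulator variant F508del (Homo sapiens) as the target, read by fluorescence, with a stated time of 25 min (a higher number here means a larger maximal response, a lower number a smaller maximal response), compound 1 `CN(C)CCN1CCN(c2nc(-c3ccccn3)nc3c2CN(Cc2ccccc2)CC3)CC1` reaches a largest response of 41.3%. Compound 2 `CN(C)CCN1CCN(c2nc(-c3cccnc3)nc3c2CN(Cc2ccccc2)CC3)CC1` is reported in this assay only as "not active" (no number reported), with no number attached. Compound 3 `CN1CCN(CCCNc2nc(-c3ccncc3)nc3c2CN(Cc2ccccc2)CC3)CC1` likewise stands in this assay as "not active" (no number reported), so no number is available for it; it shares this status with compound 2, and only compound 1 carries a figure in the set. Compound 4 `CN(C)CCN1CCN(c2nc(-c3ccncc3)nc3c2CN(Cc2ccccc2)CC3)CC1` has not yet been measured in this assay. It differs from compound 3 by 4-(2-(dimethylamino)ethyl)piperazin-1-yl in place of (3-(4-methylpiperazin-1-yl)propyl)amino on an aromatic carbon. With no numbered step available, the expectation rests on compound 3, which gives "not active" (no number reported), and on compound 1, which gives 41.3% and carries the same group as compound 4. Compound 4 is expected to reach a largest response near 15%, between 0% and 40%, with a fair chance that only inactivity is reported.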

Compound 4, largest response reached (Emax), in percent of the reference or control that the assay uses in the Cystic fibrosis transmembrane conductance regulator assay: "not active" (no number reported)
Compound 4: no number reported, and the estimate cannot be compared.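

Compound 3 and compound 4 are both "not active" in the Cystic fibrosis transmembrane conductance regulator assay, so no step can be read between them. In a physicochemical assay for solubility, read by HPLC, with a stated time of 24 h, at pH 7.4, tested at 250 uM (on this read-out higher numbers stand for higher solubility and lower numbers for lower solubility), compound 3 gives 250000 nM and compound 4 gives 250000 nM as well. The compounds shown leave open how far any single change to compound 1 shifts the maximal response. No evidence here bears on the inactivity of either compound.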